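The compounds below may be only part of what the source reports. "The series", "measured", "known", "first", "only" and "open" are said of these compounds alone.

Values from an ADME assay on the whole organism (Rattus norvegicus, strain Sprague-Dawley) for pharmacokinetics (a lower number here means slower removal, a higher number faster removal of the compound), so far are these:
Compound 1 `Cc1cc(C(F)(F)F)ccc1-c1cc2cnn([C@@H](CC(C)C)c3ccc(C(=O)NCCC(=O)O)cc3)c2cc1C` stands at 26.8 mL/min/kg
Compound 2 `Cc1cc(C(F)(F)F)ccc1-c1cc2cn([C@@H](CC(C)C)c3ccc(C(=O)NCCC(=O)O)cc3)nc2cc1C` stands at 12.7 mL/min/kg

Of these two, compound 1 holds the higher number, and compound 2 lies lower by a gap beyond the usual scatter. Compound 3 `Cc1cc2c(cnn2[C@@H](CC(C)C)c2ccc(C(=O)NCCC(=O)O)cc2)cc1-c1ccc(C(F)(F)F)cc1Cl` has not yet been measured. It keeps the core of compound 1 and alters a single substituent. The change is chloro in place of methyl on an aromatic carbon and reads, in words, chloro in place of methyl on an aromatic carbon, ortho to a large group and meta to a trifluoromethyl group. Cut one bond further out, 2-methyl-4-(trifluoromethyl)phenyl becomes 2-chloro-4-(trifluoromethyl)phenyl. Within the data shown here, no measured pair here shows this swap, so the data offer no direct guide to it. Only a small move toward a lower number in this assay is expected, with no shift beyond the scatter. The expected change is a 1.2-fold lower number from compound 1 to compound 3 (0.09 log units; within the scatter) and this estimate stays within the scatter. The estimated value for compound 3 is 22 mL/min/kg within an expected range of 11 mL/min/kg to 42 mL/min/kg overall.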

Compound 3, clearance: 18.7 mL/min/kg
Compound 3: middle estimate off by 1.2-fold (0.07 log units), on the high side; measured number inside the range.
By their numbers in this assay, from the lowest: compounds 2, 3 and 1 (each within the scatter of the next, the first and the last beyond it).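

In this assay, chloro in place of methyl on an aromatic carbon, ortho to a large group and meta to a trifluoromethyl group, gives a 1.4-fold lower number from compound 1 to compound 3 (0.16 log units; within the scatter) and so stays inside the usual scatter of the measurement. This is the first pair shown that differs in one place, and it is the first direct reading of this position: in this setting, 2-methyl-4-(trifluoromethyl)phenyl and 2-chloro-4-(trifluoromethyl)phenyl cannot be told apart by their clearance. Nothing measured alongside these numbers offers an explanation for this result.

The compounds shown carry only methyl or chloro at this place, so it remains open how a fluoro, methoxy or nitrile group there would read, and whether a change at this place can move the number beyond the scatter at all. From the compounds shown here alone, it also remains open whether the same swap would give a similar step on the core of compound 2, which has the lowest number of the three and stands beyond the scatter only from compound 1.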